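The source may report more compounds than this note shows. Statements on the series, on what has been measured and on what is new or still open speak of the compounds shown alone.

In an ADME assay on a cell-free system (plasma, Homo sapiens) for protein binding, compound 1 `COCCOc1cc2oc(=O)n(CCC(=O)O)c2cc1Cl` gives 70.7%, compound 2 `O=C(O)CCn1c(=O)oc2cc(OCC3CCC3)c(Cl)cc21` gives 98.1% and compound 3 `O=C(O)CCn1c(=O)oc2cc(OCc3ccccn3)c(Cl)cc21` gives 92.6%. Compound 3 therefore stands in the middle of the three. Compound 4 `O=C(O)CCn1c(=O)oc2cc(OCC3CC3)c(Cl)cc21` differs from it by cyclopropyl in place of pyridin-2-yl on a saturated chain carbon bound to an oxygen on an aromatic ring, with cyclopropyl in place of pyridin-2-yl on a saturated chain carbon bound to an oxygen on an aromatic ring. For the measured compounds named here, no cyclopropyl compound has been measured, so cyclobutyl in compound 2 is the nearest guide. The closest evidence is a 3.9-fold higher unbound fraction from compound 2 to compound 3 (0.59 log units; beyond the scatter), which points the other way when read in reverse. The large a 15-fold lower unbound fraction from compound 1 to compound 2 (1.19 log units; beyond the scatter) and the modest a 4.0-fold lower unbound fraction from compound 1 to compound 3 (0.60 log units; beyond the scatter) also bear on it. In this assay the expected change is a 2.1-fold lower unbound fraction from compound 3 to compound 4 (0.33 log units; beyond the scatter), a modest step. Compound 4 is estimated at 96.5%, with an expected range of 93.5% to 98.2%.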

Compound 4, plasma protein binding: 96%
Estimate against measurement, compound 4: 1.1-fold (0.06 log units) (unbound fraction) below; the measured number falls inside the stated range.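

Working notes: in this assay, cyclopropyl and pyridin-2-yl are not separated at this place (a 1.9-fold lower unbound fraction from compound 3 to compound 4 (0.27 log units; within the scatter)), so the aromatic ring and its nitrogen are not needed for a result of this size. Among the carbocycles, one ring size does register (a 2.1-fold higher unbound fraction from compound 2 to compound 4 (0.32 log units; beyond the scatter)), and cyclopropyl stays well apart from methoxymethyl (a 7.3-fold lower unbound fraction from compound 1 to compound 4 (0.86 log units; beyond the scatter)), as do the other two ring groups. Nothing on hand gives a cause for these steps.

Open, as far as these compounds go, is whether an amine or a hydroxyl on a cyclobutyl or cyclopropyl ring would bring the unbound fraction back towards that of compound 1.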